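Trisubstituted Pyridine Phenols: Moving a Hydroxyl Across a Ring

The source may hold more compounds than are shown below. What is called first, only, known or untested is meant among the compounds shown, and "the series" means these compounds.

Measured compounds:
Compound 1, `Oc1ccc(-c2cc(-c3ccccc3C(F)(F)F)cc(-c3ccccc3O)n2)cc1`, 6690 nM.
Compound 2, `Oc1ccc(-c2cc(-c3ccccc3C(F)(F)F)cc(-c3cccc(O)c3)n2)cc1`, 2750 nM.
Compound 3, `Oc1ccccc1-c1cc(-c2cccc(OC(F)(F)F)c2)cc(-c2ccccc2O)n1`, 7470 nM.

All three compounds were examined in a functional assay on DU-145 cells (Homo sapiens) for inhibition; a lower number here means a stronger inhibitor, a higher number a weaker inhibitor. Compound 1 gives 6690 nM, and compound 2, which carries 3-hydroxyphenyl in place of 2-hydroxyphenyl on an aromatic carbon, gives 2750 nM. That single change produced a 2.4-fold lower number from compound 1 to compound 2 (0.39 log units; beyond the scatter). Compound 3 gives 7470 nM, the highest of the three numbers; the difference between the core of compound 1 and the core of compound 3 is not broken down here, and compound 3 stands within the scatter of compound 1 while beyond it relative to compound 2.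

Compound 4, `Oc1cccc(-c2cc(-c3cccc(OC(F)(F)F)c3)cc(-c3ccccc3O)n2)c1`, has not yet been measured in this assay. It differs from compound 3 by 3-hydroxyphenyl in place of 2-hydroxyphenyl on an aromatic carbon. Among the measured compounds shown here, this is the same kind of change as the one from compound 1 to compound 2, though the surroundings differ: in compound 1 the position is meta to a 2-(trifluoromethyl)phenyl group and meta to a 4-hydroxyphenyl group, whereas in compound 3 it is meta to a 2-hydroxyphenyl group and meta to a large group. Because the earlier step gave a 2.4-fold lower number from compound 1 to compound 2 (0.39 log units; beyond the scatter), a step of similar size is expected here, so that compound 4 is estimated to show a 2.3-fold lower number from compound 3 to compound 4 (0.35 log units; beyond the scatter), with the estimate resting only on that one precedent. Compound 4 is therefore expected to give about 3300 nM in this assay, plausibly between 1500 nM and 7500 nM.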

Compound 4, half-maximal inhibitory concentration: > 50000 nM
Compound 4: only a limit was reported; the forecaster's own chance of this, stated with the estimate: 5%; at least 15-fold (1.18 log units) between middle value and limit.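

In this assay compound 4 reaches only a limit of the assay, > 50000 nM, so its true value is not known. Even so, putting 3-hydroxyphenyl in place of 2-hydroxyphenyl gives an at least 6.6-fold higher number from compound 3 to compound 4 (0.82 log units; beyond the scatter), and set beside the earlier case, this change does not carry from one core to the other, not even in direction: the same change on two cores in this assay, a 2.4-fold lower number (0.39 log units; beyond the scatter) from compound 1 to compound 2 and an at least 6.6-fold higher number (0.82 log units; beyond the scatter) from compound 3 to compound 4, at least 16-fold (1.21 log units) apart, beyond the scatter of two such steps This does not show which difference between the core of compound 1 and the core of compound 3 decides the outcome, and two cores are too few to set a rule for the series.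

The compounds shown leave open how the same hydroxyl move would behave on a third core, and whether the outcome on the core of compound 3 would follow the one on the core of compound 1 if the 2-hydroxyphenyl group that stays in place were changed. Going by these compounds, it also remains open whether an amine or a carboxylic acid in place of the hydroxyl on the 3-hydroxyphenyl group would give a result like that of the hydroxyl itself.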